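The source may hold more compounds than are shown below. What is called first, only, known or untested is meant among the compounds shown, and "the series" means these compounds.

Compound 1 `O=c1[nH]/c(=N\OCCCc2ccccc2)ccn1[C@@H]1O[C@H](COP(=O)(O)OP(=O)(O)OP(=O)(O)O)[C@@H](O)[C@H]1O` gives 23 nM in an in vitro functional assay on 1321-N1 cells for agonist activity at P2Y purinoceptor 4 (Homo sapiens), read by scintillation proximity assay and inositol phosphate accumulation, with a stated time of 30 min; a lower number here means that less compound is needed, a higher number that more compound is needed for the effect. Compound 2 `CC(C)(C)O/N=c1/ccn([C@@H]2O[C@H](COP(=O)(O)OP(=O)(O)OP(=O)(O)O)[C@@H](O)[C@H]2O)c(=O)[nH]1` gives 2110 nM.

Among the two numbers in this assay, compound 2 stands highest, the only measured step being a 92-fold higher number from compound 1 to compound 2 (1.96 log units; beyond the scatter). Compound 3 `CCO/N=c1/ccn([C@@H]2O[C@H](COP(=O)(O)OP(=O)(O)OP(=O)(O)O)[C@@H](O)[C@H]2O)c(=O)[nH]1` differs from compound 2 by ethyl in place of tert-butyl on an oxygen. That single step alters the same oxygen but with a different group, so it bears on the change only loosely; its size suggests that this position can move the number a long way, yet gives no direction for ethyl. The expected step is therefore a 1.4-fold lower number from compound 2 to compound 3 (0.15 log units; within the scatter), small and uncertain. Compound 3 is estimated at 1500 nM, in a range from 300 nM to 7000 nM.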

Compound 3, half-maximal effective concentration: 210 nM
For compound 3 the middle estimate is 7.1-fold (0.85 log units) above the measured one; the measured number lies below the stated range.
By their numbers in this assay, from the lowest: compound 1; then compound 3; then compound 2.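

In this assay, swapping tert-butyl for ethyl on this oxygen lowers the number markedly (a 10-fold lower number from compound 2 to compound 3 (1.00 log units; beyond the scatter)), so a small unbranched group can be far better tolerated here than a branched one. Ethyl does not match 3-phenylpropyl, however (a 9.1-fold higher number from compound 1 to compound 3 (0.96 log units; beyond the scatter)). Removing carbons from this group therefore helps in one step and hurts in the other. Nothing available explains either step. On these data alone, whether the phenyl ring or the chain length accounts for the lowest number remains open, as does how a benzyl, an isopropyl or an unbranched butyl would read here.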